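Acylguanidine series: acyl chain extension from compound 2

A few compounds are considered here, and "the series" means these few. Any claim that something is new, unique, unknown or untested is made for them only; others in the source may bear on it.

Measured so far:
compound 1 `N/C(=N\C(=O)CCc1c[nH]c2ccccc12)NCCCc1c[nH]cn1`: 77.6 nM
compound 2 `CC(=O)/N=C(\N)NCCCc1c[nH]cn1`: 813 nM
compound 3 `CN(CCC(=O)/N=C(\N)NCCCc1c[nH]cn1)C(=O)c1cc2ccccc2[nH]1`: 3550 nM

The three compounds share the same core and differ only in the acyl part on the guanidine. In a functional assay on cardiac atrium for agonist activity at histamine H2 receptor (Cavia porcellus) (on this read-out lower numbers stand for an effect already at smaller amounts and higher numbers for an effect only at larger amounts of compound), compound 2 gives 813 nM, the second highest of the three numbers. Compound 3 stands nearest to it with a higher number, beyond the scatter, and compound 1 lies furthest from it with a lower number, also beyond the scatter. Among the measured compounds shown here, no pair here differs in a single place, so no single step between measured compounds is available; the two values of compound 1 and compound 2 only show that a larger acyl group can come with a lower number, while compound 3 shows that a larger group can also come with a higher one.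

Compound 4 `CCCC(=O)/N=C(\N)NCCCc1c[nH]cn1` is not yet measured. It differs from compound 2 by ethyl in place of hydrogen on a saturated chain carbon bound to a carbonyl carbon. For the step from compound 2 to compound 4 a modest move toward a lower number is expected, of about the size a 2.3-fold lower number from compound 2 to compound 4 (0.37 log units; beyond the scatter), but it may also stay within the scatter. Compound 4 is therefore expected to give around 350 nM, with a range from 110 nM to 1500 nM.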

Compound 4, half-maximal effective concentration: 186 nM
For compound 4 the middle estimate is 1.9-fold (0.27 log units) above the measured one; the range from low to high includes it.
By their numbers in this assay, from the lowest: compound 1; then compound 4; then compound 2; then compound 3.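

In this assay, among the compounds shown here, the change from acetyl to propylcarbonyl gives a 4.4-fold lower number from compound 2 to compound 4 (0.64 log units; beyond the scatter) and so provides the first single-place step, one that lies beyond the scatter. At this saturated chain carbon bound to a carbonyl carbon, ethyl in place of hydrogen lowers the number on its own, with no ring and no hydrogen-bond donors or acceptors entering. No supporting measurement is available to explain this step.

A single step cannot show whether the number keeps falling along the chain, so a longer chain such as butyl or hexyl at this place remains the obvious open comparison. Also open, on these data alone, is how a branched chain, or a chain ending in an amine or a carboxylic acid, would compare with the ethyl of compound 4.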